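Compound 1 to compound 4: a 2-hydroxyphenyl change

A few compounds are considered here, and "the series" means these few. Any claim that something is new, unique, unknown or untested is made for them only; others in the source may bear on it.

Among the measured compounds shown here, in a functional assay on OVCAR-3 cells (Homo sapiens) for inhibition, read by MTT assay, with a stated time of 24 h (on this read-out lower numbers stand for stronger inhibition and higher numbers for weaker inhibition), compound 1 (`CC1(C)[C@H]2CC[C@]1(C)N(Cc1cn(-c3ccc(F)cc3)nn1)C(=O)C2`) gives 200 nM and holds the middle place among the three numbers so far. On the same core, compound 2 (`CC1(C)[C@H]2CC[C@]1(C)N(Cc1cn(-c3ccc(O)cc3)nn1)C(=O)C2`) reads 410 nM and compound 3 (`CC1(C)[C@H]2CC[C@]1(C)N(Cc1cn(-c3ccccc3)nn1)C(=O)C2`) reads 50 nM in this series.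

Compound 4 (`CC1(C)[C@H]2CC[C@]1(C)N(Cc1cn(-c3ccccc3O)nn1)C(=O)C2`) carries 2-hydroxyphenyl in place of 4-fluorophenyl on an aromatic nitrogen. For the measured compounds named here, its closest precedent is hydroxy in place of fluoro on an aromatic carbon, which gives a 2.1-fold higher number from compound 1 to compound 2 (0.31 log units; beyond the scatter) as a modest rise. Losing the fluoro group altogether gives a 4.0-fold lower number from compound 1 to compound 3 (0.60 log units; beyond the scatter) in the opposite direction, and an 8.2-fold lower number from compound 2 to compound 3 (0.91 log units; beyond the scatter) marks the hydroxy compound as the weakest of the three. Going by the values given here, no measured compound carries 2-hydroxyphenyl, so these steps guide the direction only loosely. A modest rise is expected in this assay with a 1.5-fold higher number from compound 1 to compound 4 (0.18 log units; within the scatter) as the estimated size. For compound 4 an estimate of 300 nM is expected, with 80 nM to 1000 nM as its range.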

Compound 4, half-maximal inhibitory concentration: 90 nM
Beside the measured number, compound 4's estimate is 3.3-fold (0.52 log units) above it; low and high end bracket the measured number.
By their numbers in this assay, from the lowest: compounds 3 and 4 (each within the scatter of the next); then compound 1; then compound 2.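

In this assay, 2-hydroxyphenyl in place of 4-fluorophenyl on the aromatic nitrogen gives a 2.2-fold lower number from compound 1 to compound 4 (0.35 log units; beyond the scatter), so a hydroxy group on the phenyl ring does not in itself bring the rise seen with 4-hydroxyphenyl. The two hydroxy isomers are clearly separated, with 2-hydroxyphenyl in place of 4-hydroxyphenyl giving a 4.6-fold lower number from compound 2 to compound 4 (0.66 log units; beyond the scatter), which shows that the read-out at this position depends on where the hydroxy group stands on the ring. Against the plain phenyl, adding the hydroxy group gives a 1.8-fold higher number from compound 3 to compound 4 (0.26 log units; within the scatter), so compound 3 and compound 4 cannot be told apart here.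

Nothing available accounts for these differences. Still open, going by these compounds, is how 2-fluorophenyl, 2-methoxyphenyl, or a phenyl ring bearing an amine or a carboxylic acid would read in this assay.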